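Aryl amine swap on the shared core

A few compounds are considered here, and "the series" means these few. Any claim that something is new, unique, unknown or untested is made for them only; others in the source may bear on it.

In a functional assay on MCF7 cells (Homo sapiens) for inhibition, read by sulforhodamine B assay (a higher number here means a weaker inhibitor, a lower number a stronger inhibitor), compound 2 `CCCc1ccc(NC2=CC(=O)c3nc4n(c3C2=O)[C@H]2OC[C@@H](O)[C@H]2OC4)cc1` gives 4660 nM. Compound 1 `O=C1C(Nc2ccc(I)cc2)=CC(=O)c2c1nc1n2[C@H]2OC[C@@H](O)[C@H]2OC1` gives 3890 nM in this assay, and the two values of compound 2 and compound 1 lie within the scatter of each other. Compound 3 `O=C1C(N2CCCC2)=CC(=O)c2c1nc1n2[C@H]2OC[C@@H](O)[C@H]2OC1` reaches only the limit > 16000 nM in this assay, a limit and not a number. Among the compounds with values here, the one measured step is an at least 4.1-fold higher number from compound 1 to compound 3 (0.61 log units; beyond the scatter), which rests on the limit (the limit of > 16000 nM in this assay, at which 1 of the 3 values shown sits).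

Compound 4 `O=C1C=C(Nc2cccc(Cl)c2)C(=O)c2c1nc1n2[C@H]2OC[C@@H](O)[C@H]2OC1` differs from compound 2 by 3-chlorophenyl in place of 4-propylphenyl on an amine nitrogen. No measured step exchanges one arylamino group for another; the only step shown, from compound 1 to compound 3, replaces the aryl amine by pyrrolidin-1-yl altogether and so gives little guidance. Compound 1 and compound 2 carry different aryl groups on that amine nitrogen and sit within the scatter of each other, so compound 4 is expected to stay near compound 2, with a step of a 1.1-fold lower number from compound 2 to compound 4 (0.05 log units; within the scatter) in this assay. Compound 4 is therefore estimated at 4200 nM, between 1500 nM and 12000 nM.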

Compound 4, half-maximal inhibitory concentration: 4720 nM
Compound 4: middle estimate off by 1.1-fold (0.05 log units), on the low side; measured number inside the range.
By their numbers in this assay, from the lowest: compounds 1, 2 and 4 (each within the scatter of the next). At a limit, above all of these: compound 3.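

This exchange of one aryl group for another on the amine nitrogen gives, in this assay, a 1.0-fold higher number from compound 2 to compound 4 (0.01 log units; within the scatter). Replacing 4-propylphenyl with 3-chlorophenyl therefore separates neither compound from the other, and compounds 1, 2 and 4 each lie within the scatter of the next, so these aryl groups on that nitrogen cannot be told apart in this assay. Nothing shown here gives a reason for this result.

Because the change replaces one substituent with another on a different ring place, the compounds shown cannot separate the effect of the group from that of its place. Going by these compounds, it also remains open whether a benzyl group or a straight alkyl chain on that amine nitrogen, or a carboxylic acid on the phenyl ring, would give a value near these.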